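Allyl for phenyl on the triazole nitrogen: a second step

A few compounds are considered here, and "the series" means these few. Any claim that something is new, unique, unknown or untested is made for them only; others in the source may bear on it.

Compound 1, `C=CCn1c(SCC(=O)Nc2ccc(/C(C)=N/O)cc2)nnc1-c1ccccc1` — 73%
Compound 2, `C/C(=N\O)c1ccc(NC(=O)CSc2nnc(-c3ccccc3)n2-c2ccccc2)cc1` — 67%
Compound 3, `COc1cc(-c2nnc(SCC(=O)Nc3ccc(C(C)=O)cc3)n2-c2ccccc2)cc(OC)c1OC` — 68%

Of the compounds shown here, three have been tested in a functional assay on the whole organism (strain albino) for inhibition, with Rattus norvegicus as the target, read by paw edema, with stated times of 30 min and 4 h, at a dose of 0.28 mmol/kg by the oral route; a lower number here means less inhibition, a higher number more inhibition at the dose given (going by the name of the read-out). Compound 1 and compound 2 share a core and differ in one place, the change being (allyl in place of phenyl on an aromatic nitrogen). This change made a step of a number 6 percentage points higher from compound 2 to compound 1 (within the scatter), so the two numbers lie within the usual scatter of each other and no order between them can be read. Compound 3 differs from compound 2 in more than one place, and the difference between the two cores is not broken down here; in this assay compound 3 gives 68%, which sits within the scatter of both others.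

Compound 4, `C=CCn1c(SCC(=O)Nc2ccc(C(C)=O)cc2)nnc1-c1cc(OC)c(OC)c(OC)c1`, has not yet been measured. It arises from compound 3 by allyl in place of phenyl on an aromatic nitrogen. Among the measured compounds shown here, this is the same kind of change as the one from compound 2 to compound 1, but not the same: in compound 3 the aromatic nitrogen is next to the ring atom that bears a 3,4,5-trimethoxyphenyl group, whereas in compound 2 it is next to the ring atom that bears a phenyl group.

For the measured compounds named here, the expectation for compound 4 therefore rests on the one earlier step, a number 6 percentage points higher from compound 2 to compound 1 (within the scatter), carried over onto the core of compound 3. Compound 4 is estimated to give 73% in this assay, a step of a number 5 percentage points higher from compound 3 to compound 4 (within the scatter), because compound 3 gives 68% and the earlier step was small. The estimated range for compound 4 is 60% to 84%.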

Compound 4, a percentage reported as inhibition, in the whole organism at one dose (the size of the read-out at that dose, not a potency): 68%
For compound 4 the middle estimate is 5 percentage points above the measured one; the range from low to high includes it.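

In this assay, allyl in place of phenyl on the aromatic nitrogen gives no change at the digits printed from compound 3 to compound 4 (within the scatter), and set beside the earlier step, the two readings cannot be told apart: the same change on two cores in this assay, a number 6 percentage points higher (within the scatter) from compound 2 to compound 1 and no change at the digits printed (within the scatter) from compound 3 to compound 4, 6 percentage points apart, within the scatter of two such steps. On these two cores, then, the change carries over without any difference that stands clear of the scatter, and neither step can be read as a gain or a loss. Among the compounds shown here, this does not show that the change is without effect in general: there are only two steps, each read at a single dose as a percentage and not as a potency, and they say nothing about how the change would behave on a further core.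

The compounds shown leave open whether a different group on that aromatic nitrogen, such as a propyl chain or a benzyl group, would read the same in this assay. They also leave open how the 3,4,5-trimethoxyphenyl group acts on its own, as the two cores differ in more than one place, and whether a carboxylic acid or an amine at the far end of the molecule would give a different reading.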